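Amide substituent swap: aryl to methoxyethyl

The compounds below may be only part of what the source reports. "The series", "measured", "known", "first", "only" and "open" are said of these compounds alone.

Among the measured compounds shown here, compound 2 `COc1ccc2nc(C)cc(OCC(=O)Nc3ccc(C)cc3)c2c1` is the only compound with a number in an ADME assay on HepG2 cells (Homo sapiens) for cytotoxicity, read by trypan blue exclusion, with a stated time of 48 h, in the presence of a further agent that is not named here (on this read-out lower numbers stand for higher toxicity in this test and higher numbers for lower toxicity in this test), giving 41500 nM. Compound 1 `COc1ccc2nc(C)cc(OCC(=O)Nc3ccccc3Cl)c2c1` gives > 140000 nM, a limit and not a number, matching (the limit of > 140000 nM in this assay, at which 1 of the 2 values shown sits). For the measured compounds named here, the one measured step, an at least 3.3-fold lower number from compound 1 to compound 2 (0.52 log units; beyond the scatter), exchanges one aryl group for another. Compound 3 `COCCNC(=O)COc1cc(C)nc2ccc(OC)cc12` differs from compound 2 by 2-methoxyethyl in place of 4-methylphenyl on an amide-type nitrogen. Going by the values given here, no measured step covers an aryl-to-alkyl exchange, so the expectation rests loosely on the direction of an at least 3.3-fold lower number from compound 1 to compound 2 (0.52 log units; beyond the scatter) reversed. The expected step is a 2.2-fold higher number from compound 2 to compound 3 (0.34 log units; beyond the scatter), toward lower toxicity. Compound 3 is estimated at 90000 nM, between 30000 nM and 160000 nM.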

Compound 3, half-maximal cytotoxic concentration: > 164000 nM
Compound 3: no number, only a limit; the forecaster's own chance of this, stated with the estimate: 40%; middle value at least 1.8-fold (0.26 log units) away from the limit.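

In this assay, among the compounds shown here, the first exchange of an aryl group for a non-aromatic chain on the amide-type nitrogen, 2-methoxyethyl in place of 4-methylphenyl, gives an at least 3.9-fold higher number from compound 2 to compound 3 (0.59 log units; beyond the scatter), whereas the earlier step only exchanged one aryl group for another. Compound 3 gives > 164000 nM, which is a limit and not a number. The step between compound 1 and compound 3 cannot be read.

Whether the ring leaving or the ether oxygen entering accounts for the change remains open. A plain butyl chain or a 2-aminoethyl group on this nitrogen would help separate the two.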